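This account rests on a few compounds, and the source may have more. Where it says the series, first, only, none or still open, it means among the compounds named here.

Compound 1 `Nc1cc(N)c2nc(-c3ccccc3)c(Oc3ccc(Cl)c(Cl)c3)nc2c1` carries a 3,4-dichlorophenoxy group on the shared core. In a functional assay on NCI-H23 cells (Homo sapiens) for inhibition, read by sulforhodamine B assay, with a stated time of 48 h (on this read-out higher numbers stand for weaker inhibition of growth and lower numbers for stronger inhibition of growth), compound 1 gives 15500 nM. Its nearest measured neighbour is compound 2 `CCOC(=O)[C@H](CCC(=O)O)NC(=O)c1ccc(Oc2nc3cc(N)cc(N)c3nc2-c2ccccc2)cc1`, which carries a different group on the same oxygen; in this assay compound 2 gives 15500 nM, so the two compounds stand level at the digits recorded, and nothing separates them beyond the usual scatter of this measurement. Among the compounds with values here, compound 1 thus stands at a value it shares with the only other measured compound.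

Compound 3 `Nc1cc(N)c2nc(-c3ccccc3)c(Oc3ccc(F)cc3)nc2c1` differs from compound 1 in one place: 4-fluorophenyl in place of 3,4-dichlorophenyl on an oxygen on an aromatic ring. Within the data shown here, no pair of measured compounds shows this change, so no measured step exists to lean on, and the two measured values give no hint of direction. The author therefore expects little movement in this assay, at most a shift inside the scatter, with a slight lean toward weaker inhibition of growth. The step expected in this assay is a 1.3-fold higher number from compound 1 to compound 3 (0.11 log units; within the scatter). Compound 3 is estimated at 20000 nM, with a likely range from 6000 nM to 65000 nM.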

Compound 3, concentration for 50% growth inhibition: 20900 nM
Compound 3: the middle estimate sits 1.0-fold (0.02 log units) below what was measured, and the stated range covers the measured number.
By their numbers in this assay, from the lowest: compounds 1, 2 and 3 (each within the scatter of the next).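

Read at the group on the oxygen, 4-fluorophenyl in place of 3,4-dichlorophenyl gives a 1.3-fold higher number from compound 1 to compound 3 (0.13 log units; within the scatter) in this assay and is the first step measured at this place. Trading two chlorine atoms for one fluorine on the same carbon-only aromatic ring, with one heavy atom fewer, leaves the number inside the usual scatter, so this read-out does not tell these two halogen-bearing phenyl groups apart. Nothing measured here offers a reason for this.

On these data alone, whether this place responds at all stays open, as a single step within the scatter says nothing about groups of another kind, such as an amine or a carboxylic acid on the phenyl ring, or a longer alkyl chain on the oxygen in place of the ring. The compounds shown also leave open whether changes to the phenyl group on the shared core or to its two amino groups would move the number in this assay beyond the scatter.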